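This account rests on a few compounds, and the source may have more. Where it says the series, first, only, none or still open, it means among the compounds named here.

Compound 1 `COc1cc(OCc2cccc(-c3ccc(C(F)(F)F)cn3)c2)c2cc(-c3cn4nc(OC)sc4n3)oc2c1` gives 0.733 h in an ADME assay on microsomes from liver (Homo sapiens) for metabolic stability; a lower number here means that the compound disappears faster, a higher number that the compound lasts longer. Compound 2 `COc1cc(OCc2csc(-c3ccc(C(N)=O)cc3)n2)c2cc(-c3cn4nc(OC)sc4n3)oc2c1` gives 1.38 h in this assay, and the two numbers lie within the usual scatter of each other, so this evidence does not separate them. Compound 3 `COc1cc(OCc2cccc(-c3cncnc3)c2)c2cc(-c3cn4nc(OC)sc4n3)oc2c1` has not yet been measured. It carries pyrimidin-5-yl in place of the 5-(trifluoromethyl)pyridin-2-yl of compound 1, on an aromatic carbon of a six-membered aromatic ring of carbon only, meta to a large group (pyrimidin-5-yl in place of 5-(trifluoromethyl)pyridin-2-yl on an aromatic carbon). For the measured compounds named here, no measured pair shows this exchange on its own, so the data offer no direct guide to it. Going by the values given here, the only reference is compound 1 at 0.733 h alongside compound 2 at 1.38 h. On that basis the expected step, a 1.4-fold higher number from compound 1 to compound 3 (0.13 log units; within the scatter), is estimated to stay within the scatter, with no firm direction. The estimate for compound 3 is 1 h, with an expected range from 0.4 h to 2.5 h.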

Compound 3, half-life: 0.117 h
Compound 3: middle estimate off by 8.5-fold (0.93 log units), on the high side, outside the stated range (below it).
By their numbers in this assay, from the lowest: compound 3; then compounds 1 and 2 (each within the scatter of the next).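

In this assay, for the compounds shown here, the exchange of 5-(trifluoromethyl)pyridin-2-yl for pyrimidin-5-yl gives a 6.3-fold lower number from compound 1 to compound 3 (0.80 log units; beyond the scatter) and is the first single change that can be read. It shows that this place, on an aromatic carbon of a six-membered aromatic ring of carbon only, is not indifferent to the group it carries: with the rest of compound 1 unchanged, this exchange alone moves the half-life beyond the scatter. No available evidence bears on the origin of this step.

From the compounds shown here alone, the exchange removes the trifluoromethyl group and alters the ring's nitrogen count in one move, so the share of each in the step remains open. An unsubstituted pyridin-2-yl or a 4-(trifluoromethyl)phenyl group at this place would begin to separate the two.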